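Halogen swap on the aryl arm of the shared core

A few compounds are considered here, and "the series" means these few. Any claim that something is new, unique, unknown or untested is made for them only; others in the source may bear on it.

The shared core is carried by compound 1 `OCC(O)Cn1nc2c(Br)c(Br)c(Br)c(Br)c2n1`, compound 2 `OC(CCn1nc2c(Br)c(Br)c(Br)c(Br)c2n1)c1ccc(Br)cc1` and compound 3 `OC(CCn1nc2c(Br)c(Br)c(Br)c(Br)c2n1)c1cccc(Cl)c1`. In a functional assay on CCRF-CEM cells (Homo sapiens) for antiproliferative activity, read by MTT assay, with a stated time of 48 h, tested at 100 uM (on this read-out lower numbers stand for a stronger effect and higher numbers for a weaker effect at the one concentration tested), compound 1 gives 1%, compound 2 gives 0% and compound 3 gives 0%; compound 2 is level with compound 3 at the digits shown, and all three values lie within the scatter of one another. Compound 4 `OC(CCn1nc2c(Br)c(Br)c(Br)c(Br)c2n1)c1ccc(Cl)cc1` differs from compound 2 by chloro in place of bromo on an aromatic carbon. Going by the values given here, the one measured step that bears on this, no change at the digits printed from compound 2 to compound 3 (within the scatter), exchanged one halogenated phenyl for another without movement. No step beyond the scatter is therefore expected in this assay for compound 4, with a number 1 percentage points higher from compound 2 to compound 4 (within the scatter) as the expected step. Compound 4 is estimated at 1%, in the range 0% to 10%.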

Compound 4, a percentage reported as activity, at one concentration (the size of the read-out at that concentration, not a potency): 0%
Beside the measured number, compound 4's estimate is 1 percentage points above it; the measured number falls inside the stated range.
By their numbers in this assay, from the lowest: compounds 2, 3, 4 and 1 (each within the scatter of the next).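

Chloro in place of bromo on the aromatic carbon reads as no change at the digits printed from compound 2 to compound 4 (within the scatter) and 4-chlorophenyl in place of 3-chlorophenyl reads as no change at the digits printed from compound 3 to compound 4 (within the scatter) in this assay at the one concentration tested. Neither the identity of this halogen nor its place on the phenyl ring separates these compounds here, and all the readings lie at the low end of the scale. No evidence on the cause is available.

Open, from the compounds shown here alone, is whether a plain phenyl, or a phenyl carrying an amine or a carboxylic acid, would lift the reading from this low end. Also open, going by these compounds, is whether these halogen variants would separate at lower concentrations.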